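This account rests on a few compounds, and the source may have more. Where it says the series, first, only, none or still open, it means among the compounds named here.

In a toxicity assay on Vero cells (Chlorocebus sabaeus) for inhibition (on this read-out lower numbers stand for an effect already at smaller amounts and higher numbers for an effect only at larger amounts of compound), three compounds sharing one core have been measured: compound 1 `COc1cccc(NC(=O)c2nnn(CC3CCNCC3)c2N)c1`, compound 2 `COc1cccc(NC(=O)c2nnn(C(C)c3ccc(C(C)(C)C)cc3)c2N)c1` and compound 3 `COc1cccc(NC(=O)c2nnn(CC3CCN(C(=O)OC(C)(C)C)CC3)c2N)c1`. Compound 1 gives > 50100 nM, which is a limit of the assay and not a number. Compound 3 gives > 50100 nM, which is also a limit. Compound 1 therefore stands at the limit of > 50100 nM in this assay, at which 2 of the 3 values shown sit, with no readable value of its own.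

The step of interest leads to compound 4 `COc1cccc(NC(=O)c2nnn(Cc3ccc(C4CC4)cc3)c2N)c1`, and the structural change is 4-cyclopropylphenyl in place of piperidin-4-yl on a saturated chain carbon bound to an aromatic nitrogen. A 4-cyclopropylphenyl thus replaces piperidin-4-yl on a saturated chain carbon bound to an aromatic nitrogen.

For the measured compounds named here, the only measured step from compound 1 is a step that the two limits leave unreadable from compound 1 to compound 3, so it offers no size to carry over. The nearest guide is compound 2, which, like compound 4, has a six-membered aromatic ring of carbon only on that chain. Compound 2 gives a true number, 39800 nM. On that basis a modest move towards effect at smaller amounts is expected in this assay, although a result at the limit would be no surprise. The expected step is an at least 1.2-fold lower number from compound 1 to compound 4 (0.09 log units; that floor lies within the scatter). For compound 4 the estimated value is 40000 nM, with an expected range from 16000 nM to 63000 nM.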

Compound 4, half-maximal effective concentration: > 50100 nM
Compound 4 gave a limit, no number (the forecaster's own chance of this, stated with the estimate: 45%); middle value at least 1.2-fold (0.09 log units) away from the limit.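

Compound 4 gives > 50100 nM, which is a limit of the assay and not a number. No new step can be read between compound 1 and compound 4, since both sit at the same limit: the limit of > 50100 nM in this assay, at which 3 of the 4 values shown sit.

The compounds shown leave open where compound 1, compound 3 and compound 4 truly stand in this assay, and whether 4-cyclopropylphenyl in place of piperidin-4-yl changes the value at all.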